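This account rests on a few compounds, and the source may have more. Where it says the series, first, only, none or still open, it means among the compounds named here.

Compound 3 `OC1CCc2cccc(Nc3ncc(-c4ccc(Cl)cc4)o3)c2C1` gives 15 nM in an in vitro functional assay on cells for antagonist activity at transient receptor potential cation channel subfamily V member 1 (Homo sapiens), read by FLIPR and calcium flux (on this read-out higher numbers stand for weaker inhibition and lower numbers for stronger inhibition), the lowest of the three numbers recorded so far. Compound 2 `CC(C)(C)c1ccc(-c2cnc(Nc3cccc4c3CC(O)CC4)o2)cc1` gives 26 nM in this assay, and the step of a 1.7-fold lower number from compound 2 to compound 3 (0.24 log units; within the scatter) lies within the scatter, so these two cannot be ordered. Compound 1 `OC1CCc2cccc(Nc3ncc(-c4ccccc4)o3)c2C1` gives 187 nM in this assay, and the step of a 12-fold lower number from compound 1 to compound 3 (1.10 log units; beyond the scatter) is a large one. The next compound, compound 4 `COc1ccc(-c2cnc(Nc3cccc4c3CC(O)CC4)o2)cc1`, differs from compound 3 by methoxy in place of chloro on an aromatic carbon. For the measured compounds named here, no measured step involves methoxy, so the change is judged from neighbouring steps: a 12-fold lower number from compound 1 to compound 3 (1.10 log units; beyond the scatter) and a 7.2-fold lower number from compound 1 to compound 2 (0.86 log units; beyond the scatter), where two different groups in place of hydrogen each lowered the number beyond the scatter, and a 1.7-fold lower number from compound 2 to compound 3 (0.24 log units; within the scatter), where exchanging one of those groups for the other stayed within it. A third group on the same aromatic carbon is therefore expected to give a number between those of compound 1 and compound 3, closer to compound 3. Compound 4 is estimated at 40 nM, with a range of 15 nM to 120 nM, which corresponds to an expected step of a 2.7-fold higher number from compound 3 to compound 4 (0.43 log units; beyond the scatter).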

Compound 4, half-maximal inhibitory concentration: 81 nM
Compound 4: middle estimate off by 2.0-fold (0.31 log units), on the low side; the range from low to high includes it.
By their numbers in this assay, from the lowest: compounds 3 and 2 (each within the scatter of the next); then compound 4; then compound 1.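

At this aromatic carbon, chloro and tert-butyl could not be ordered, but in this assay methoxy separates from both, with steps beyond the scatter (a 5.4-fold higher number from compound 3 to compound 4 (0.73 log units; beyond the scatter)) and (a 3.1-fold higher number from compound 2 to compound 4 (0.49 log units; beyond the scatter)). Methoxy still improves on hydrogen (a 2.3-fold lower number from compound 1 to compound 4 (0.36 log units; beyond the scatter)), though by a smaller step than either of the other two groups gave. The lowering seen earlier therefore does not come with equal size for every group placed here: among the three groups shown, its size depends on which group enters.

No measurement offered here explains why methoxy gives a smaller step than chloro or tert-butyl. As far as these compounds go, it remains open whether fluoro, trifluoromethyl, a nitrile or an amine on this carbon would stand with chloro and tert-butyl or nearer methoxy.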